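A few compounds are considered here, and "the series" means these few. Any claim that something is new, unique, unknown or untested is made for them only; others in the source may bear on it.

Compound 1 `CCC(C)c1ccc(Nc2nc(C)cs2)cc1` and compound 2 `Cc1csc(Nc2ccc(COCC(F)(F)F)cc2)n1` share the same core and were both tested in an ADME assay on microsomes from liver (Rattus norvegicus) for metabolic stability, with a stated time of 30 min, tested at 1 uM; on this read-out lower numbers stand for a less stable compound and higher numbers for a more stable compound. Compound 1 gives 0% in this assay, and compound 2 gives 1%, so compound 1 has the lowest of the two numbers, with compound 2 lying only a hair higher, within the scatter, so the two cannot be told apart. Compound 3 `CCNCc1ccc(Nc2nc(C)cs2)cc1` has not yet been measured in this assay. It differs from compound 1 in one place: (ethylamino)methyl in place of sec-butyl on an aromatic carbon. For the measured compounds named here, no step between two measured compounds shows the effect of such a change here, so any expectation rests only on the near-zero readings of compound 1 and compound 2. Because compound 1 sits at 0%, the number can hardly fall further, and a small upward step a number 8 percentage points higher from compound 1 to compound 3 (within the scatter) is expected, of a size that stays within the scatter. Compound 3 is therefore estimated at 8% in this assay, in the range 0% to 30%.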

Compound 3, percent of the compound remaining: 0%
Beside the measured number, compound 3's estimate is 8 percentage points above it; measured number inside the range.
By their numbers in this assay, from the lowest: compounds 1, 3 and 2 (each within the scatter of the next).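

In this assay, the step with (ethylamino)methyl in place of sec-butyl on an aromatic carbon reads no change at the digits printed from compound 1 to compound 3 (within the scatter), so a group with 1 hydrogen-bond donor and 1 hydrogen-bond acceptor does not lift the number off the bottom of the read-out at this position. The step with ethylamino in place of 2,2,2-trifluoroethoxy on a saturated chain carbon bound to an aromatic carbon reads a number 1 percentage points lower from compound 2 to compound 3 (within the scatter), so this exchange in the chain does not separate the compounds either. Nothing shown here gives a reason for these readings.

On these data alone, whether a carboxylic acid, a tertiary amine or a longer chain at this position would give a number clear of the scatter stays open. So does whether a change elsewhere on the shared core would do so.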